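The source may report more compounds than this note shows. Statements on the series, on what has been measured and on what is new or still open speak of the compounds shown alone.

Compound 1 (`C[C@@H](c1ccc(OC(F)F)cc1)N1CC[C@](CCC(N)=O)(c2ccc(F)cc2)OC1=O`) – > 1.5 h
Compound 2 (`C[C@@H](c1ccc(-c2ccc3ncnn3c2)cc1)N1CC[C@](CC(C)(C)O)(c2ccccc2)OC1=O`) – > 1.5 h

In an ADME assay on microsomes from liver (Homo sapiens) for metabolic stability (on this read-out lower numbers stand for a shorter-lived compound and higher numbers for a longer-lived compound), compound 2 gives a limit and not a number (> 1.5 h). Compound 1 also gives only a limit (> 1.5 h). The two measured compounds therefore share one limit (the limit of > 1.5 h in this assay, at which 2 of the 2 values shown sit). Compound 3 (`Cc1cc(-c2ccc([C@H](C)N3CC[C@](CC(C)(C)O)(c4ccccc4)OC3=O)cc2)cc(C)n1`) carries 2,6-dimethylpyridin-4-yl on an aromatic carbon, para to a large group, where compound 2 has a larger group with two aromatic rings (a group of 8 heavy atoms (7 carbon, 1 nitrogen; one six-membered aromatic ring with 1 hetero atom) in place of a group of 9 heavy atoms (6 carbon, 3 nitrogen; one five-membered aromatic ring with 3 hetero atoms, one six-membered aromatic ring with 1 hetero atom), on an aromatic carbon). For the measured compounds named here, no measured step shows what such a swap does, so the expected step is small, within the usual scatter and slightly downward if anything (an at least 1.1-fold lower number from compound 2 to compound 3 (0.06 log units; that floor lies within the scatter)). Compound 3 is expected to give an estimated half-life (1.3 h) with an estimated range (0.7 h to 1.5 h).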

Compound 3, half-life: > 0.75 h
Compound 3 ended at the assay's limit; the forecaster's own chance of this, stated with the estimate: 60%; the middle value lies beyond the limit too.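

Compound 2 and compound 3 both give only limits, not numbers, in this assay; the step between them cannot be read. As far as these compounds go, whether 2,6-dimethylpyridin-4-yl shortens or lengthens half-life compared with the group it replaces stays open.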